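Lengthening the alkyl chain: from compound 2 to compound 3

The compounds below may be only part of what the source reports. "The series", "measured", "known", "first", "only" and "open" are said of these compounds alone.

Measured so far:
compound 1 `Cc1cccc(-c2n[nH]c(-c3ccccc3)n2)c1` — > 20 mg/kg
compound 2 `CCc1ccccc1-c1n[nH]c(-c2ccccc2)n1` — 0.15 mg/kg

For the measured compounds named here, in a functional assay on the whole organism (Cricetulus griseus) with Cricetinae gen. sp. as the target (on this read-out lower numbers stand for an effect already at smaller amounts and higher numbers for an effect only at larger amounts of compound), compound 2 gives 0.15 mg/kg, the only actual number in this assay so far. For compound 1 the result is a limit, > 20 mg/kg (the limit of > 20 mg/kg in this assay, at which 1 of the 2 values shown sits). Compound 3 `CCCCc1ccccc1-c1n[nH]c(-c2ccccc2)n1` differs from compound 2 by ethyl in place of hydrogen on a saturated chain carbon, two bonds along the chain from an aromatic carbon. Going by the values given here, no measured pair shows a change of this kind, so no step beyond the usual scatter is expected in this assay, in either direction. Compound 3 is therefore estimated at 0.2 mg/kg, with a range of 0.05 mg/kg to 0.8 mg/kg. The expected step is a 1.3-fold higher number from compound 2 to compound 3 (0.12 log units; within the scatter).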

Compound 3, dose for half-maximal effect: 17 mg/kg
Compound 3: the middle estimate sits 85-fold (1.93 log units) below what was measured; the measured number lies above the stated range.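

In this assay, ethyl in place of hydrogen on the chain gives a 110-fold higher number from compound 2 to compound 3 (2.05 log units; beyond the scatter), so this saturated chain does not accept added length freely. An addition of only 2 carbon, with no ring, no hydrogen-bond donor or acceptor and no net charge, is enough for a step of this size. Nothing measured here gives a cause for the step.

Open: whether propyl already shows the same loss, or whether it appears only with butyl. Also open, on these data alone, is how a chain ending in an amine or a hydroxyl would read out at this place.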